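A few compounds are considered here, and "the series" means these few. Any claim that something is new, unique, unknown or untested is made for them only; others in the source may bear on it.

Working notes on the series.

Compound 1 `CC1=C(C(=O)OC(C)(C)C)C(c2ccoc2)NC(=O)N1` gives 2% in an assay on membranes from HeLa cells for displacement of a labelled ligand from adenosine receptor A3 (Homo sapiens), read by scintillation counting, with a stated time of 180 min, tested at 1 uM; on this read-out higher numbers stand for more inhibition at the one concentration tested (going by the name of the read-out) and lower numbers for less inhibition. Compound 2 `CC1=C(C(=O)OCc2ccccc2)C(c2ccoc2)NC(=O)N1` gives 1% in this assay, and compound 3 `CC1=C(C(=O)OC(C)(C)C)C(c2ccsc2)NC(=O)N1` gives 1%. Compound 1 thus carries the highest of the three numbers, but the gaps to compound 2 and to compound 3 are both within the scatter, so no ordering among the three can be read from them. The two single-point steps from compound 1 are a number 1 percentage points lower from compound 1 to compound 2 (within the scatter) and a number 1 percentage points lower from compound 1 to compound 3 (within the scatter); neither moves the read-out beyond the scatter, and all three numbers sit close to the floor of the read-out.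

Compound 4 `CCCC(=O)C1=C(C)NC(=O)NC1c1ccoc1` differs from compound 1 in one place: propyl in place of tert-butoxy on a carbonyl carbon. Among the compounds with values here, of the measured steps, only the one from compound 1 to compound 2 touches the same carbonyl region, and it was within the scatter; the step to compound 3 concerns the ring on the saturated carbon and does not bear on this change. With nothing in the series showing a step beyond the scatter, no step beyond the scatter is expected in this assay for compound 4 either. The expected step is no change at the digits printed from compound 1 to compound 4 (within the scatter). Compound 4 is estimated at 2%, with a range from -5% to 10%.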

Compound 4, a percentage reported as inhibition, at one concentration (the size of the read-out at that concentration, not a potency): 2%
Estimate against measurement, compound 4: no gap at the digits printed, within the range that was stated.
By their numbers in this assay, from the lowest: compounds 2, 3, 1 and 4 (each within the scatter of the next).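

In this assay, exchanging the ester-type tert-butoxy for propyl on this carbonyl carbon gives no change at the digits printed from compound 1 to compound 4 (within the scatter). The earlier step in this region kept the oxygen on the carbonyl carbon, whereas this one removes it, so propyl brings no hydrogen-bond acceptor and fewer heavy atoms, and the read-out still does not move beyond the scatter. With every number in the series close to the floor, this flat step cannot show whether the position matters, and no evidence bears on the result.

On these data alone, it remains open whether an amine, a carboxylic acid or a longer chain on this carbonyl carbon would move the number beyond the scatter. The single tested concentration also leaves open how these compounds would read at any other concentration.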